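Carbonyl substituent change from compound 3 to compound 4

This account rests on a few compounds, and the source may have more. Where it says the series, first, only, none or still open, it means among the compounds named here.

Measured so far in a functional assay on Caco-2 cells (Homo sapiens), read by MTT assay, with a stated time of 48 h (on this read-out higher numbers stand for weaker inhibition and lower numbers for stronger inhibition), for three compounds:
compound 1 `CCn1c(C(=O)NCCN(C)C)ccc1C(CC)(CC)c1ccc(OCC(=O)C(C)(C)C)c(C)c1` gives 1600 nM
compound 2 `CCN(CC)CCCNC(=O)c1ccc(C(CC)(CC)c2ccc(OCC(=O)C(C)(C)C)c(C)c2)n1CC` gives 1000 nM
compound 3 `CCN(CC)CCCNC(=O)c1ccc(C(CC)(CC)c2ccc(OCC(O)C(C)(C)C)c(C)c2)n1CC` gives 1800 nM

Compound 3 stands at 1800 nM in this assay and lies within the scatter of both other compounds. Next is compound 4 `CCn1c(C(=O)N(C)CCC#N)ccc1C(CC)(CC)c1ccc(OCC(O)C(C)(C)C)c(C)c1` which carries (2-cyanoethyl)(methyl)amino in place of (3-(diethylamino)propyl)amino on a carbonyl carbon.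

The measured steps bear on this only in part. Placing (diethylamino)methyl where dimethylamino stood gave a 1.6-fold lower number from compound 1 to compound 2 (0.20 log units; within the scatter) and shows how little that chain change moved the number. Placing 1-hydroxy-2,2-dimethylpropyl where (tert-butyl)carbonyl stood gave a 1.8-fold higher number from compound 2 to compound 3 (0.26 log units; within the scatter) and compound 4 retains the hydroxylated group. Going by the values given here, neither step removes the terminal amine, and no measured compound lacks one, so the series gives no direct measure of the present change. A modest move to a higher number is expected, with wide uncertainty. The estimated step is a 2.2-fold higher number from compound 3 to compound 4 (0.35 log units; beyond the scatter) on this limited evidence. Compound 4 is estimated at 4000 nM in this assay with an expected range from 1200 nM to 15000 nM for that measurement.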

Compound 4, half-maximal inhibitory concentration: > 50000 nM
Compound 4: a limit, no number; the forecaster's own chance of this, stated with the estimate: 15%; middle value at least 12-fold (1.09 log units) away from the limit.
By their numbers in this assay, from the lowest: compounds 2, 1 and 3 (each within the scatter of the next). At a limit, above all of these: compound 4.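

In this assay, compound 4 is recorded as a limit and not as a number: the limit of > 50000 nM in this assay, at which 1 of the 4 values shown sits.

Replacing (3-(diethylamino)propyl)amino with (2-cyanoethyl)(methyl)amino on a carbonyl carbon gives an at least 27-fold higher number from compound 3 to compound 4 (1.44 log units; beyond the scatter), whereas the two earlier steps both lie within the scatter. Going by these compounds alone, the earlier changes altered the amine chain or the hydroxylated group while a terminal amine remained, so this carbonyl substituent is the first place where a change registers clearly in this read-out. The change is a composite, however: the terminal diethylamino group and the amide hydrogen leave together, a nitrile enters, and the step alone cannot assign the result to any one of these.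

A (3-(diethylamino)propyl)(methyl)amino group would test the amide hydrogen apart from the amine, while a (2-cyanoethyl)amino group would test the nitrile chain with that hydrogen kept. Going by these compounds, a morpholine or a carboxylic acid at the chain end, and the (tert-butyl)carbonyl form paired with the (2-cyanoethyl)(methyl)amino group, also remain open.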